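Fluorophenyl in place of methylpyridinyl on the shared ether

The compounds below may be only part of what the source reports. "The series", "measured", "known", "first", "only" and "open" are said of these compounds alone.

Compound 1 `O=C1NC(=O)C(Cc2ccc(Oc3ccccc3)cc2)S1`: 307 nM
Compound 2 `Cc1ccc(Oc2ccc(CC3SC(=O)NC3=O)cc2)cc1`: 547 nM
Compound 3 `Cc1cccc(Oc2ccc(CC3SC(=O)NC3=O)cc2)n1`: 2620 nM

In a functional assay for agonist activity at Free fatty acid receptor 1 (Homo sapiens), read by FLIPR, in the presence of a further agent that is not named here (a lower number here means that less compound is needed, a higher number that more compound is needed for the effect), compound 3 has the highest number of the three. The step of an 8.5-fold higher number from compound 1 to compound 3 (0.93 log units; beyond the scatter) and the step of a 4.8-fold higher number from compound 2 to compound 3 (0.68 log units; beyond the scatter) both lie beyond the scatter, while the step of a 1.8-fold higher number from compound 1 to compound 2 (0.25 log units; within the scatter) does not. Compound 4 `O=C1NC(=O)C(Cc2ccc(Oc3ccc(F)cc3)cc2)S1` carries the change (4-fluorophenyl in place of 6-methylpyridin-2-yl on an oxygen on an aromatic ring), which removes the ring with a nitrogen and brings back a carbon-only ring like those of compound 1 and compound 2. Because compound 1 gave 307 nM and compound 2 gave 547 nM, a step back downward is expected, roughly reversing the earlier rises. The estimated step is a 7.5-fold lower number from compound 3 to compound 4 (0.87 log units; beyond the scatter), with compound 4 expected near 350 nM, in the range 150 nM to 900 nM.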

Compound 4, half-maximal effective concentration: 480 nM
For compound 4 the middle estimate is 1.4-fold (0.14 log units) below the measured one; the range from low to high includes it.
By their numbers in this assay, from the lowest: compounds 1, 4 and 2 (each within the scatter of the next); then compound 3.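

In this assay, putting 4-fluorophenyl in place of 6-methylpyridin-2-yl on this oxygen gives a 5.5-fold lower number from compound 3 to compound 4 (0.74 log units; beyond the scatter), so among these compounds only the ring with a nitrogen stands apart. Fluoro and methyl on the carbon-only ring cannot be told apart (a 1.1-fold lower number from compound 2 to compound 4 (0.06 log units; within the scatter)), and neither can fluoro and hydrogen (a 1.6-fold higher number from compound 1 to compound 4 (0.19 log units; within the scatter)). No measurement at hand explains these results.

Going by these compounds, it remains open whether the ring nitrogen or the methyl of compound 3 goes with its higher number. On these data alone, how an amine or a carboxylic acid on this ring would read also remains open.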